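Amino in Place of Nitro, Repeated on a Second Core

The source may report more compounds than this note shows. Statements on the series, on what has been measured and on what is new or still open speak of the compounds shown alone.

Measured in a functional assay on HT-1080 cells (Homo sapiens) for antiproliferative activity, read by MTT assay, with a stated time of 72 h; a lower number here means a stronger inhibitor, a higher number a weaker inhibitor:
compound 1, `COc1ccc(-c2c(-c3cc(OC)c(OC)c(OC)c3)ssc2=S)cc1[N+](=O)[O-]`, gives 3550 nM
compound 2, `COc1ccc(-c2c(-c3cc(OC)c(OC)c(OC)c3)ssc2=S)cc1N`, gives 3000 nM
compound 3, `COc1ccc(-c2ssc(=O)c2-c2cc(OC)c(OC)c(OC)c2)cc1[N+](=O)[O-]`, gives 4220 nM

Compound 1 and compound 2 share one core, and compound 3 is built on another; how the core of compound 3 differs from the core of compound 1 is not broken down here. The three numbers all lie within the usual scatter of one another, so no order among them can be read from these data. Between compound 1 and compound 2 the change is amino in place of nitro on an aromatic carbon, and it made a 1.2-fold lower number from compound 1 to compound 2 (0.07 log units; within the scatter).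

Compound 4, `COc1ccc(-c2ssc(=O)c2-c2cc(OC)c(OC)c(OC)c2)cc1N`, is not yet measured. It is related to compound 3 by amino in place of nitro on an aromatic carbon, the same change, at a place described in the same words as for compound 1 and compound 2. On that basis compound 4 is expected to behave much as compound 2 did relative to compound 1: the step of a 1.2-fold lower number from compound 3 to compound 4 (0.08 log units; within the scatter) is expected to be small, because in the earlier pair the same change gave a 1.2-fold lower number from compound 1 to compound 2 (0.07 log units; within the scatter). Compound 4 is therefore estimated at 3500 nM in this assay, with a likely range from 1700 nM to 7500 nM, resting on a single earlier pair and so held loosely.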

Compound 4, half-maximal inhibitory concentration: 147 nM
Beside the measured number, compound 4's estimate is 24-fold (1.38 log units) above it; measured number below the stated range.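

In this assay, for the compounds shown here, amino in place of nitro on an aromatic carbon gave a 29-fold lower number from compound 3 to compound 4 (1.46 log units; beyond the scatter), a large step, whereas the same change on the core of compound 1 gave no step that can be read, so its size did not carry from one core to the other: the same change on two cores in this assay, a 1.2-fold lower number (0.07 log units; within the scatter) from compound 1 to compound 2 and a 29-fold lower number (1.46 log units; beyond the scatter) from compound 3 to compound 4, 24-fold (1.38 log units) apart, beyond the scatter of two such steps. For this series, then, a result for this change on one core was no safe guide to its size on the other, and the core it stands on has to be counted as part of the change. Going by these compounds alone, this rests on only two pairs, however, and it does not show which feature of the core matters, why the two steps differ, or how the change would behave on any further core.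

The compounds shown leave open whether the large step belongs to the amino group itself, which a hydroxyl group, a methylamino group or an acetamide at the same place on the core of compound 3 could test. They also leave open whether the step survives when the neighbouring methoxy group gives way to an ethoxy group or a fluorine atom.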